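This account rests on a few compounds, and the source may have more. Where it says the series, first, only, none or still open, it means among the compounds named here.

Compound 1 `CCCOC(=O)C1=C(C)NC(=S)NC1c1ccco1` gives 1%
Compound 2 `CCCOC(=O)C1=C(C)NC(=S)NC1c1ccoc1` gives 3%

Both numbers come from an assay on membranes from HeLa cells for displacement of a labelled ligand from adenosine receptor A3 (Homo sapiens), read by scintillation counting, with a stated time of 180 min, tested at 1 uM; on this read-out lower numbers stand for less inhibition and higher numbers for more inhibition at the one concentration tested (going by the name of the read-out). Compound 2 has the higher of the two numbers, but the gap to compound 1 is small: the step of a number 2 percentage points higher from compound 1 to compound 2 (within the scatter) lies within the scatter, so the two compounds cannot be told apart on this read-out, and neither can be said to give the higher inhibition in this assay.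

Compound 3 `CC1=C(C(=O)OCc2ccccc2)C(c2ccoc2)NC(=S)N1` has not yet been measured in this assay . It differs from compound 2 in one place: phenyl in place of ethyl on a saturated chain carbon bound to an oxygen next to a carbonyl group. Among the measured compounds shown here, the only measured step in this set concerns the furan ring on a saturated ring carbon and says nothing about the ester chain, so no measured step bears directly on the change from compound 2 to compound 3. With both measured numbers close to the bottom of the read-out, the expectation for compound 3 is a step of about a number 1 percentage points higher from compound 2 to compound 3 (within the scatter), that is, none beyond the scatter. On that basis compound 3 is estimated at 4% in this assay , with a range from -8% to 16%.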

Compound 3, a percentage reported as inhibition, at one concentration (the size of the read-out at that concentration, not a potency): 20%
Compound 3: middle estimate off by 16 percentage points, on the low side; the measured number lies above the stated range.
By their numbers in this assay, from the lowest: compounds 1 and 2 (each within the scatter of the next); then compound 3.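

In this assay, the chain on the ester turns out to be a place where the read-out can move: the change from propyl to benzyl gives a number 17 percentage points higher from compound 2 to compound 3 (beyond the scatter), whereas the earlier step between the furan-2-yl and furan-3-yl groups stayed within the scatter. Phenyl in place of ethyl, on a saturated chain carbon bound to an oxygen next to a carbonyl group, is thus the first change here that separates two compounds, although the step is modest and rests on this single pair. Nothing at hand accounts for the higher number seen with the benzyl group.

The compounds shown leave open whether the step belongs to the aromatic ring itself or simply to the added carbon atoms, a question that a cyclohexylmethyl group in the same place would address, and whether a longer chain such as phenethyl would carry the number further. They also leave open whether furan-2-yl in place of furan-3-yl would still make no difference alongside the benzyl group, and how an amine or a carboxylic acid on the phenyl ring would read in this assay.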